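A few compounds are considered here, and "the series" means these few. Any claim that something is new, unique, unknown or untested is made for them only; others in the source may bear on it.

Of the compounds shown here, three sharing one core have been tested in a functional assay on MCF7 cells (Homo sapiens) for inhibition, read by sulforhodamine B assay, with a stated time of 48 h; a lower number here means a stronger inhibitor of growth, a higher number a weaker inhibitor of growth. Compound 1 `CN1CCN(CCCOc2cccc3nc(Nc4ccc(Cl)c(C(F)(F)F)c4)ccc23)CC1` gives 1410 nM, compound 2 `CN1CCN(CCCOc2cccc3nc(Nc4ccc(Cl)c(F)c4)ccc23)CC1` gives 1310 nM, and compound 3 `CN1CCN(CCCOc2cccc3nc(Nc4ccc(F)c(F)c4)ccc23)CC1` gives 3330 nM, the highest of the three numbers. The step of a 1.1-fold lower number from compound 1 to compound 2 (0.03 log units; within the scatter) changed little, whereas the steps of a 2.5-fold higher number from compound 2 to compound 3 (0.41 log units; beyond the scatter) and a 2.4-fold higher number from compound 1 to compound 3 (0.37 log units; beyond the scatter) both raised the number. Compound 4 `CN1CCN(CCCOc2cccc3nc(Nc4cc(Cl)cc(Cl)c4)ccc23)CC1` has not yet been measured; it differs from compound 3 by 3,5-dichlorophenyl in place of 3,4-difluorophenyl on a nitrogen on an aromatic ring. Since putting fluoro in place of chloro raised the number in the step of a 2.5-fold higher number from compound 2 to compound 3 (0.41 log units; beyond the scatter), bringing chlorine back is expected to lower it in this assay, by roughly a 2.4-fold lower number from compound 3 to compound 4 (0.38 log units; beyond the scatter). For compound 4 the estimated value is therefore 1400 nM, with a likely range from 600 nM to 3500 nM.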

Compound 4, concentration for 50% growth inhibition: 1380 nM
Compound 4: the middle estimate sits 1.0-fold (0.01 log units) above what was measured; measured number inside the range.
By their numbers in this assay, from the lowest: compounds 2, 4 and 1 (each within the scatter of the next); then compound 3.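

In this assay the step of a 2.4-fold lower number from compound 3 to compound 4 (0.38 log units; beyond the scatter) shows that chlorine can restore the lower number without a 4-chloro group, which both earlier compounds with lower numbers carried. The steps of a 1.1-fold higher number from compound 2 to compound 4 (0.02 log units; within the scatter) and a 1.0-fold lower number from compound 1 to compound 4 (0.01 log units; within the scatter) leave compound 4 level with them, so at this position 3,5-dichlorophenyl serves as well as either 4-chloro ring. No supporting data explain why these rings match or why 3,4-difluorophenyl gives the higher number.

Still open, as far as these compounds go, is whether a single chlorine would be enough. It is also unknown how a plain phenyl, a methoxyphenyl or a 3,5-dimethylphenyl would behave on this nitrogen.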